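A Ring Methyl on Compound 3

The source may report more compounds than this note shows. Statements on the series, on what has been measured and on what is new or still open speak of the compounds shown alone.

In a physicochemical assay for solubility, read by HPLC, in phosphate buffer, with a stated time of 24 h, at pH 7.4, tested at 100 uM (on this read-out higher numbers stand for higher solubility and lower numbers for lower solubility), compound 3 (`CC(CCCCC(=O)NO)Nc1c(Nc2ccccc2)c(=O)c1=O`) gives 93000000 nM as its reading. Its closest neighbour is compound 1 (`O=C(CCCCCNc1c(Nc2ccccc2)c(=O)c1=O)NO`), which gives 47000000 nM as its reading. The step between them is a 2.0-fold higher number from compound 1 to compound 3 (0.30 log units; within the scatter) and so cannot be told apart from repeat-to-repeat noise. Compound 2 (`Cc1ccc(Nc2c(NCCCCCC(=O)NO)c(=O)c2=O)cc1`) stands clearly lower, with 8100000 nM as its reading.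

Compound 4 (`Cc1ccc(Nc2c(NC(C)CCCCC(=O)NO)c(=O)c2=O)cc1`) has not yet been measured. It differs from compound 3 by a single change, methyl in place of hydrogen on an aromatic carbon, which turns phenyl into 4-methylphenyl. That same change has been measured only once, as a 5.8-fold lower number from compound 1 to compound 2 (0.76 log units; beyond the scatter) and this modest step lies beyond the scatter. For the measured compounds named here, it is the one direct guide available, and no measured pair shows whether the change behaves alike in a compound that also carries the chain methyl of compound 3. A drop of similar size is therefore expected, and the estimated step is a 5.8-fold lower number from compound 3 to compound 4 (0.76 log units; beyond the scatter) in this assay as a working figure. For compound 4 the expected value is 16000000 nM (estimated range 5000000 nM to 50000000 nM).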

Compound 4, solubility: 83000000 nM
Estimate against measurement, compound 4: 5.2-fold (0.71 log units) below; the whole stated range lies below it.
By their numbers in this assay, from the lowest: compound 2; then compounds 1, 4 and 3 (each within the scatter of the next).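

The ring methyl that turns phenyl into 4-methylphenyl does not act the same way in every compound: in this assay it gives a 1.1-fold lower number from compound 3 to compound 4 (0.05 log units; within the scatter), whereas without the chain methyl it gave a 5.8-fold lower number from compound 1 to compound 2 (0.76 log units; beyond the scatter). Read along the other edge of the set, the chain methyl gives a 10-fold higher number from compound 2 to compound 4 (1.01 log units; beyond the scatter) when the ring methyl is present, against a 2.0-fold higher number from compound 1 to compound 3 (0.30 log units; within the scatter) when that ring carbon carries only hydrogen. The two methyls therefore do not simply add up, and compound 2, with the ring methyl alone, is the one that stands apart from both of its single-change neighbours, compound 1 and compound 4.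

Nothing given here accounts for this interplay between the two methyls. For the compounds shown here, it also remains open whether the same pattern would hold for a chlorine atom or a methoxy group on that ring carbon, or for an ethyl group in place of the chain methyl, since these four compounds cover only one small group at each of the two places.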